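Amino for methoxy on an iodinated acyclic purine nucleoside

This account rests on a few compounds, and the source may have more. Where it says the series, first, only, none or still open, it means among the compounds named here.

In an ADME assay on L1210/0 cells (Mus musculus) for cytotoxicity, with a stated time of 48 h (a lower number here means a stronger inhibitor, a higher number a weaker inhibitor), compound 1 `Nc1ncnc2c1ncn2C[C@@H]1C[C@H](CO)c2ccccc21` gives a result that is only a limit, > 200000 nM. Compound 2 `COc1ncnc2c1ncn2C[C@@H]1C[C@H](CO)c2ccccc21` likewise shows only a limit in this assay, > 200000 nM. The step that the two limits leave unreadable from compound 2 to compound 1 is therefore unreadable, because of the limit of > 200000 nM in this assay, at which 3 of the 3 values shown sit. Compound 3 `COc1nc(I)nc2c1ncn2COCCO` also reaches only a limit in this assay, > 200000 nM. The difference between the core of compound 3 and the core of compound 2 is not broken down here.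

Compound 4 `Nc1nc(I)nc2c1ncn2COCCO` has not yet been tested. It differs from compound 3 by amino in place of methoxy on an aromatic carbon. Compound 1 differs from compound 2 by amino in place of methoxy on an aromatic carbon; the two changes are the same kind of change, but in compound 4 the place is also meta to an iodo group. Since all three results sit at a limit, compound 4 is expected to show a step that the limit leaves unreadable from compound 3 to compound 4, with an estimated value near 300000 nM, most likely again only a limit.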

Compound 4, half-maximal inhibitory concentration: > 200000 nM
Compound 4 gave a limit, no number (the forecaster's own chance of this, stated with the estimate: 85%); the middle value is on the limit's open side.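

No step from compound 3 to compound 4 can be read, as both results are only limits in this assay: the limit of > 200000 nM in this assay, at which 4 of the 4 values shown sit.

The compounds shown leave open how amino and methoxy compare on either core.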